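A few compounds are considered here, and "the series" means these few. Any claim that something is new, unique, unknown or untested is made for them only; others in the source may bear on it.

In a functional assay on MDA-MB-231 cells (Homo sapiens) for inhibition, read by MTT assay, with a stated time of 72 h (a lower number here means a stronger inhibitor, a higher number a weaker inhibitor), three compounds sharing one core differ only in the group on an aromatic carbon. Compound 1 `c1ccc(-c2nc(CNc3nccc(NC4CC4)n3)cs2)cc1`, with cyclopropylamino, reports only a limit of the assay, > 100000 nM. Compound 2 `c1ccc(-c2nc(CNc3nccc(NC4CCCCC4)n3)cs2)cc1`, with cyclohexylamino, gives 18500 nM. Compound 3 `c1ccc(-c2nc(CNc3nccc(N4CCCC4)n3)cs2)cc1`, with pyrrolidin-1-yl, gives 18300 nM. It therefore stands level with the cyclohexylamino analogue, as a 1.0-fold lower number from compound 2 to compound 3 (0.00 log units; within the scatter) shows. Both analogues lie clear of the cyclopropylamino compound, with an at least 5.4-fold lower number from compound 1 to compound 2 (0.73 log units; beyond the scatter) and an at least 5.4-fold lower number from compound 1 to compound 3 (0.73 log units; beyond the scatter).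

Compound 4 `OC1CC2CC1CN2c1ccnc(NCc2csc(-c3ccccc3)n2)n1` keeps the core and replaces the pyrrolidin-1-yl of compound 3 at the same aromatic carbon: a group of 8 heavy atoms (6 carbon, 1 nitrogen, 1 oxygen; one five-membered non-aromatic ring of carbon only, one five-membered non-aromatic ring with 1 hetero atom) in place of a group of 5 heavy atoms (4 carbon, 1 nitrogen; one five-membered non-aromatic ring with 1 hetero atom), on an aromatic carbon. The entering group has one five-membered non-aromatic ring with 1 hetero atom, as the leaving group does, and adds one five-membered non-aromatic ring of carbon only.

Among the compounds with values here, no measured step tests this group directly. The closest guide is a 1.0-fold lower number from compound 2 to compound 3 (0.00 log units; within the scatter), which shows two different groups giving the same number, while an at least 5.4-fold lower number from compound 1 to compound 3 (0.73 log units; beyond the scatter) shows that this position can move the number in this assay. A modest change in either direction is possible, but the expectation is for none beyond the scatter, with a 1.2-fold higher number from compound 3 to compound 4 (0.08 log units; within the scatter) as the estimated step. Compound 4 is expected at about 22000 nM, with an estimated range from 7000 nM to 70000 nM.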

Compound 4, half-maximal inhibitory concentration: 6460 nM
The estimate for compound 4 lay 3.4-fold (0.53 log units) above the measured number, and the stated range ends above it.
By their numbers in this assay, from the lowest: compound 4; then compounds 3 and 2 (each within the scatter of the next). At a limit, above all of these: compound 1.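

In this assay, within the data shown here, the group of compound 4 is the first at this aromatic carbon to move the number below the level shared by compounds 2 and 3, with a 2.8-fold lower number from compound 3 to compound 4 (0.45 log units; beyond the scatter) and a 2.9-fold lower number from compound 2 to compound 4 (0.46 log units; beyond the scatter). Among these compounds, the earlier compounds showed only that two different groups could give the same number and that the cyclopropylamino compound stood apart from them, whereas this result shows that the position still has room for a lower number once a five-membered carbon ring and an oxygen are added to the pyrrolidine-type ring. The widest gap in the series is an at least 15-fold lower number from compound 1 to compound 4 (1.18 log units; beyond the scatter), but compound 1 stands at a limit, so this step has no fixed upper end: the limit of > 100000 nM in this assay, at which 1 of the 4 values shown sits.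

The added carbon ring and the oxygen enter together in compound 4, so the compounds shown cannot separate what each contributes to the lower number. A simple hydroxypyrrolidin-1-yl group would carry the oxygen without the added ring, while a morpholin-4-yl group would place an oxygen within a single ring, and neither is among the compounds shown here.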